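A Second Methyl on a Retinoid Biaryl Acid

The source may report more compounds than this note shows. Statements on the series, on what has been measured and on what is new or still open speak of the compounds shown alone.

Compound 1 `CC1(C)CCC(C)(C)c2cc(-c3cccc(-c4ccc(C(=O)O)cc4)c3)ccc21`: 2.3 nM in an assay on CV-1 cells (Cercopithecidae) for activation of retinoic acid receptor gamma (Homo sapiens); a lower number here means that less compound is needed, a higher number that more compound is needed for the effect
Compound 2 `Cc1ccc(-c2ccc(C(=O)O)cc2)cc1-c1ccc2c(c1)C(C)(C)CCC2(C)C`: < 1 nM, a limit of this assay rather than a number

Compound 2 therefore stands at the limit of < 1 nM in this assay, at which 1 of the 2 values shown sits; only the upper end of its position is known. Compound 3 `Cc1ccc(-c2ccc(C(=O)O)cc2)cc1-c1cc2c(cc1C)C(C)(C)CCC2(C)C` differs from compound 2 by methyl in place of hydrogen on an aromatic carbon. Within the data shown here, the one measured step that resembles this change is the earlier methyl in place of hydrogen on an aromatic carbon, which gave an at least 2.3-fold lower number from compound 1 to compound 2 (0.36 log units; beyond the scatter); it sits on a different ring, however, so it is only a loose guide. Since compound 2 is already at the limit, a further gain could not be seen, whereas a loss would be. Compound 3 is expected to stay close to the limit, estimated at 1.5 nM with a range from 0.3 nM to 8 nM, that is an expected step of an at least 1.5-fold higher number from compound 2 to compound 3 (0.17 log units; that floor lies within the scatter).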

Compound 3, concentration for half-maximal activity: 1 nM
Compound 3: the middle estimate sits 1.5-fold (0.18 log units) above what was measured; the measured number falls inside the stated range.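

Compound 3 shows that the aromatic carbon of the fused system, ortho to a large group, can carry a methyl while a low number remains: in this assay compound 3 gives 1 nM, a measured value rather than a limit, giving a number no lower from compound 2 to compound 3 (the limit leaves the size open). Among these compounds, the earlier methyl sat on a different ring, so the earlier compounds said nothing about this place. Compound 2 stands at a limit of the assay, so the size of the step to compound 3 cannot be read, and neither a loss nor a gain can be stated: the limit of < 1 nM in this assay, at which 1 of the 3 values shown sits.

The compounds shown leave open how an ethyl group or a methoxy group would read at this place. They also leave open whether this methyl would give a similar number without the methyl on the other ring.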